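The source may hold more compounds than are shown below. What is called first, only, known or untested is meant among the compounds shown, and "the series" means these compounds.

Measured in a functional assay on the whole organism with Mus musculus as the target, in the maximal electroshock model; a lower number here means that less compound is needed, a higher number that more compound is needed for the effect:

Compound 1 `C=CC(N)CCC(=O)N1CCCC(C(=O)OC)C1`: > 540 umol/kg, a limit
Compound 2 `C=CC(N)CCC(=O)N1CCCC1=O`: > 540 umol/kg, a limit
Compound 3 `C=CC(CCC(=O)OC)NC(=O)C1CCNCC1`: > 540 umol/kg, a limit

None of the three compounds has given a number in this assay. Compound 3 stands at > 540 umol/kg, and this value is a limit. It shares that position with both other compounds, so the whole set comes down to a single reading: the limit of > 540 umol/kg in this assay, at which 3 of the 3 values shown sit. Going by the values given here, the set therefore offers no ranking, and no measured pair differs in just one place.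

The next compound, compound 4 `C=CC(CCC(=O)OC)NC(=O)C1CCCNC1`, has the same atoms as compound 3, joined differently. The change is piperidin-3-yl in place of piperidin-4-yl on a carbonyl carbon. In words, piperidin-3-yl stands in place of piperidin-4-yl on a carbonyl carbon, and the rest of the structure stays as it was.

Among the compounds with values here, with no measured step to draw on, the expectation rests on compound 3 and its > 540 umol/kg. No change beyond the usual scatter is expected, and no direction is favoured, so the estimated step of a number no higher from compound 3 to compound 4 (the limit leaves the size open) is expected to be small. The assay may well report only a limit again. For compound 4 the estimate is 540 umol/kg, with an expected range from 200 umol/kg to 1000 umol/kg.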

Compound 4, dose for half-maximal effect: > 540 umol/kg
Compound 4 was reported as a limit (the forecaster's own chance of this, stated with the estimate: 75%); the middle value sits exactly at the limit.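

In this assay compound 4 gives > 540 umol/kg, which is a limit of the assay. Going by these compounds alone, compound 3 also gives only a limit, so no step from compound 3 to compound 4 can be read. The compounds shown leave open how any of them ranks in this assay and whether piperidin-3-yl and piperidin-4-yl differ there at all, as every reading is the same: the limit of > 540 umol/kg in this assay, at which 4 of the 4 values shown sit.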